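Thiourea series: nitric oxide inhibition, toward compound 4

This account rests on a few compounds, and the source may have more. Where it says the series, first, only, none or still open, it means among the compounds named here.

Measured so far: compound 1 `COc1ccc(NC(=S)NCc2ccccc2)cc1`; compound 2 `S=C(Nc1ccccc1)N1CCN(c2ncccn2)CC1`; compound 3 `S=C(NCc1ccccc1)N1CCN(c2ncccn2)CC1`.

In a functional assay on RAW264.7 cells (Mus musculus) for inhibition, read by Griess assay, with a stated time of 24 h (a lower number here means a stronger inhibitor, a higher number a weaker inhibitor), compound 1 gives >= 200000 nM, a limit of the assay. Compound 2 gives >= 200000 nM, also a limit. Compound 3 gives >= 200000 nM, again a limit. For the measured compounds named here, the one single-point step, a step that the two limits leave unreadable from compound 2 to compound 3, cannot be read, since (the limit of >= 200000 nM in this assay, at which 3 of the 3 values shown sit). Compound 2 thus stands only at a limit, with no number to set against the other two.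

Compound 4 `CCCCN1CCN(C(=S)Nc2ccccc2)CC1` differs from compound 2 by butyl in place of pyrimidin-2-yl on an amine nitrogen in a ring. Going by the values given here, no measured step bears on this change, and no reading so far leaves the limit. For compound 4 the expected step is a number no higher from compound 2 to compound 4 (the limit leaves the size open), that is none beyond the scatter. Compound 4 is therefore estimated at 200000 nM, within 50000 nM to 600000 nM, most likely again reported only as a limit.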

Compound 4, half-maximal inhibitory concentration: >= 200000 nM
Compound 4: a limit, no number; the forecaster's own chance of this, stated with the estimate: 75%; the middle value lies on the limit itself.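

Compound 4, like compound 2, stands only at a limit, so no step between them can be read: the limit of >= 200000 nM in this assay, at which 4 of the 4 values shown sit.

The compounds shown leave open how butyl and pyrimidin-2-yl compare in this assay, and which change, if any, gives a readable number there.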